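A few compounds are considered here, and "the series" means these few. Any claim that something is new, unique, unknown or untested is made for them only; others in the source may bear on it.

Compound 1 `CCCCCCCc1ccc(-c2c(C)[nH]c(=O)n2C)cc1` gives 8400 nM
Compound 2 `CCCCCOc1ccc(-c2c(C)[nH]c(=O)n2C2CCCCC2)cc1` gives 9100 nM
Compound 3 `CCCCCCOc1ccc(-c2c(C)[nH]c(=O)n2C2CCCCC2)cc1` gives 8500 nM

All three were measured in a functional assay on brain (Rattus norvegicus, strain Wistar) for inhibition (a lower number here means a stronger inhibitor, a higher number a weaker inhibitor), and their values lie within the scatter of one another, so compound 3 stands level with both others. Compound 4 `CCCCCCCc1ccc(-c2c(C)[nH]c(=O)n2C2CCCCC2)cc1` differs from compound 3 in one place, where heptyl replaces hexyloxy on an aromatic carbon (heptyl in place of hexyloxy on an aromatic carbon). Among the measured compounds shown here, no measured step makes exactly this swap. The closest one (a 1.1-fold lower number from compound 2 to compound 3 (0.03 log units; within the scatter)) put methyl in place of hydrogen on the chain and stayed within the scatter. Compound 1 already carries heptyl, with another group on the core, and its 8400 nM sits within the scatter of compound 3. No step beyond the scatter is therefore expected in this assay for this change. The expected step is no change at the digits printed from compound 3 to compound 4 (within the scatter) and no more. For compound 4 the estimate is 8500 nM with 4000 nM to 18000 nM as the expected range.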

Compound 4, half-maximal inhibitory concentration: 8700 nM
For compound 4 the middle estimate is 1.0-fold (0.01 log units) below the measured one, within the range that was stated.
By their numbers in this assay, from the lowest: compounds 1, 3, 4 and 2 (each within the scatter of the next).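

Heptyl in place of hexyloxy on the aromatic carbon gives a 1.0-fold higher number from compound 3 to compound 4 (0.01 log units; within the scatter) in this assay, so losing the oxygen of the chain leaves the number unmoved beyond the scatter. Heptyl in place of pentyloxy gives a 1.0-fold lower number from compound 2 to compound 4 (0.02 log units; within the scatter), and cyclohexyl in place of methyl on the aromatic nitrogen gives a 1.0-fold higher number from compound 1 to compound 4 (0.02 log units; within the scatter), so among these compounds neither site has yet separated one compound from another. No independent measurement bears on why these values stay level. Going by these compounds, whether a much shorter chain, or an amine or a carboxylic acid on the chain, would shift the number remains open.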